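From One Chlorine to Two on the Aryl Group

The compounds below may be only part of what the source reports. "The series", "measured", "known", "first", "only" and "open" are said of these compounds alone.

Measured in an assay on microsomes from intestine for inhibition of acyl-CoA:cholesterol acyltransferase (Oryctolagus cuniculus); a higher number here means a weaker inhibitor, a lower number a stronger inhibitor:
compound 1, `COc1ccccc1NC(=O)NCC1(c2ccccc2)CCCCC1`, gives 270 nM
compound 2, `Cc1ccccc1NC(=O)NCC1(c2ccccc2)CCCCC1`, gives 640 nM
compound 3, `O=C(NCC1(c2ccccc2)CCCCC1)Nc1ccc(Cl)cc1`, gives 2200 nM

Compound 3 carries the highest number of the three, hence is the weakest inhibitor shown, with an 8.1-fold higher number from compound 1 to compound 3 (0.91 log units; beyond the scatter) and a 3.4-fold higher number from compound 2 to compound 3 (0.54 log units; beyond the scatter) both beyond the scatter. Compound 4, `O=C(NCC1(c2ccccc2)CCCCC1)Nc1cccc(Cl)c1Cl`, differs from compound 3 in one place: 2,3-dichlorophenyl in place of 4-chlorophenyl on an amide-type nitrogen. Among the compounds with values here, no measured step adds a second chlorine, so the bearing steps are indirect: 2-methoxyphenyl and 2-methylphenyl both gave lower numbers than 4-chlorophenyl, a modest spread. A differently substituted phenyl in compound 4 may therefore pull the number back down, though with real uncertainty. Compound 4 is expected near 700 nM, between 200 nM and 2500 nM. The expected step is a 3.1-fold lower number from compound 3 to compound 4 (0.50 log units; beyond the scatter).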

Compound 4, half-maximal inhibitory concentration: 1300 nM
Beside the measured number, compound 4's estimate is 1.9-fold (0.27 log units) below it; measured number inside the range.
By their numbers in this assay, from the lowest: compound 1; then compound 2; then compounds 4 and 3 (each within the scatter of the next).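

With a 1.7-fold lower number from compound 3 to compound 4 (0.23 log units; within the scatter), 2,3-dichlorophenyl and 4-chlorophenyl on the amide-type nitrogen cannot be told apart in this assay, so this change to the chlorine substitution gives no clear shift. The dichloro compound also stays behind the two compounds without chlorine, as a 2.0-fold higher number from compound 2 to compound 4 (0.31 log units; beyond the scatter) and a 4.8-fold higher number from compound 1 to compound 4 (0.68 log units; beyond the scatter) show, although the first of these steps only just clears the scatter. No measurement shown here explains these differences. Still open, as far as these compounds go, is how a phenyl carrying an amine or a carboxylic acid would compare. Also open, from the compounds shown here alone, is whether a methoxy and a chlorine together on one phenyl would give a lower number than either alone.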